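Fluoro in Place of Trifluoromethyl on the Aryl Hydrazone

The source may report more compounds than this note shows. Statements on the series, on what has been measured and on what is new or still open speak of the compounds shown alone.

Two acylhydrazones sharing one trimethoxybenzoyl core have been measured in a functional assay on PC-3 cells (Homo sapiens) for antiproliferative activity, read by MTT assay, tested at 1 uM; on this read-out lower numbers stand for a weaker effect and higher numbers for a stronger effect at the one concentration tested. Compound 1 `COc1cc(C(=O)N/N=C/c2cccc(F)c2)cc(OC)c1OC` gives 53.5% in this assay. Compound 2 `COc1cc(C(=O)N/N=C/c2ccc(C(F)(F)F)cc2)cc(OC)c1OC` gives 59.9% in this assay. The gap between compound 2 and compound 1 lies within the scatter, so compound 2 cannot be ranked against compound 1 on these two numbers; its value simply sits alongside that of compound 1. Among the measured compounds shown here, no step between measured compounds differing in one place is available.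

Compound 3 `COc1cc(C(=O)N/N=C/c2ccc(F)cc2)cc(OC)c1OC` has not yet been measured in this assay. It differs from compound 2 as follows: fluoro in place of trifluoromethyl on an aromatic carbon. With only the two values of compound 1 and compound 2 as guidance, no step beyond the scatter is expected in this assay, in either direction. Compound 3 is therefore estimated at 53%, within a range from 35% to 68%, which corresponds to an expected step of a number 6.9 percentage points lower from compound 2 to compound 3 (within the scatter).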

Compound 3, a percentage reported as inhibition, at one concentration (the size of the read-out at that concentration, not a potency): 76%
The estimate for compound 3 lay 23 percentage points below the measured number; measured number outside the range, above it.
By their numbers in this assay, from the lowest: compounds 1 and 2 (each within the scatter of the next); then compound 3.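

In this assay, fluoro in place of trifluoromethyl on the aromatic carbon para to a large group gives a number 16.1 percentage points higher from compound 2 to compound 3 (beyond the scatter), which shows that the read-out responds to the group at this position, something the two earlier values could not show. The 4-fluorophenyl in place of 3-fluorophenyl gives a number 22.5 percentage points higher from compound 1 to compound 3 (beyond the scatter), so with fluoro on both sides of this comparison, where it sits on the ring also matters. Nothing available explains either step.

From the compounds shown here alone, whether a chloro, a methoxy or an amine at this position would match, exceed or fall short of the value of compound 3 remains open. Also open, going by these compounds, is whether these steps would hold at other concentrations, since a single concentration gives the size of the effect and not a potency.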